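The compounds below may be only part of what the source reports. "The series", "measured", "known", "first", "only" and "open" are said of these compounds alone.

Measured so far:
Compound 1 `Cc1ccccc1NC(=O)CCC(=O)OCCCCCCSc1ccc([N+](=O)[O-])c2nonc12` gives 1410 nM
Compound 2 `O=C(CCC(=O)OCCCCCCSc1ccc([N+](=O)[O-])c2nonc12)Nc1ccc(F)cc1` gives 1740 nM

Both numbers come from an ADME assay on HUVEC cells (Homo sapiens) for cytotoxicity, read by MTT assay, with a stated time of 72 h; on this read-out higher numbers stand for weaker inhibition and lower numbers for stronger inhibition. Compound 1 and compound 2 share the same core and differ only in the aromatic group on the amide-type nitrogen, and their values cannot be told apart: a 1.2-fold higher number from compound 1 to compound 2 (0.09 log units; within the scatter). Compound 2 therefore stands together with compound 1 rather than apart from it.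

Compound 3 `COc1ccc(NC(=O)CCC(=O)OCCCCCCSc2ccc([N+](=O)[O-])c3nonc23)cc1OC` has not yet been measured in this assay. It differs from compound 2 in one place: 3,4-dimethoxyphenyl in place of 4-fluorophenyl on an amide-type nitrogen. For the measured compounds named here, the only measured step that bears on this change is the one from compound 1 to compound 2, which also exchanged the aromatic group on the amide-type nitrogen and stayed within the scatter. On that basis no step beyond the scatter is expected, and the estimated step is a 1.0-fold lower number from compound 2 to compound 3 (0.01 log units; within the scatter). Compound 3 is expected to give about 1700 nM in this assay, with a range from 800 nM to 3600 nM.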

Compound 3, half-maximal inhibitory concentration: 870 nM
The estimate for compound 3 lay 2.0-fold (0.29 log units) above the measured number, and the stated range covers the measured number.
By their numbers in this assay, from the lowest: compounds 3, 1 and 2 (each within the scatter of the next).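

In this assay, a larger aromatic group carrying two hydrogen-bond acceptors, 3,4-dimethoxyphenyl, gives a 2.0-fold lower number from compound 2 to compound 3 (0.30 log units; within the scatter) and a 1.6-fold lower number from compound 1 to compound 3 (0.21 log units; within the scatter). This is the largest step seen so far at this position, yet it still stays within the scatter, so all three aromatic groups on the amide-type nitrogen remain indistinguishable in this assay, even though the entering group has more heavy atoms and brings oxygen in place of fluorine. No measurement at hand speaks to what lies behind these numbers.

The compounds shown leave open how the number responds when the amide-type nitrogen carries a group without an aromatic ring, such as cyclohexyl, or a group bearing an amine or a carboxylic acid. Going by these compounds, all three also keep the same chain and shared core, so the effect of a longer chain remains unknown.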